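Morpholine amide in place of the anilide in compound 4

A few compounds are considered here, and "the series" means these few. Any claim that something is new, unique, unknown or untested is made for them only; others in the source may bear on it.

Three compounds of this series share one core and differ only at the amide end of the chain. In an assay on isolated protein for inhibition of glutathione S-transferase Mu 2 (Homo sapiens), with a stated time of 10 min (a higher number here means a weaker inhibitor, a lower number a stronger inhibitor), compound 1 `O=C(CCC(=O)OCCCCCCSc1ccc([N+](=O)[O-])c2nonc12)Nc1ccccc1` gives 700 nM, compound 2 `O=C(CCC(=O)OCCCCCCSc1ccc([N+](=O)[O-])c2nonc12)Nc1ccccc1Cl` gives 330 nM and compound 3 `COc1ccc(NC(=O)CCC(=O)OCCCCCCSc2ccc([N+](=O)[O-])c3nonc23)cc1` gives 130 nM. Compound 3 has the lowest number of the three; the steps leading to it are a 5.4-fold lower number from compound 1 to compound 3 (0.73 log units; beyond the scatter) and a 2.5-fold lower number from compound 2 to compound 3 (0.40 log units; beyond the scatter), both beyond the scatter, and the remaining step is a 2.1-fold lower number from compound 1 to compound 2 (0.33 log units; beyond the scatter).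

Compound 4 `O=C(CCC(=O)N1CCOCC1)OCCCCCCSc1ccc([N+](=O)[O-])c2nonc12` takes the change (morpholin-4-yl in place of (4-methoxyphenyl)amino on a carbonyl carbon). Among the measured compounds shown here, no measured step covers this kind of change: each step so far alters or swaps a substituent on the aromatic ring of the anilide, and each moved the number only modestly. Removing that aromatic ring altogether, with its amide hydrogen, is a larger change than any of those, and both substituted anilides (compound 2 and compound 3) gave lower numbers than the bare one (compound 1). A shift to a higher number is therefore expected rather than a further drop. For compound 4 the expected step is a 6.9-fold higher number from compound 3 to compound 4 (0.84 log units; beyond the scatter). The estimate for compound 4 in this assay is 900 nM, with a range from 250 nM to 3500 nM.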

Compound 4, half-maximal inhibitory concentration: 170 nM
For compound 4 the middle estimate is 5.3-fold (0.72 log units) above the measured one; the measured number lies below the stated range.
By their numbers in this assay, from the lowest: compounds 3, 4 and 2 (each within the scatter of the next, the first and the last beyond it); then compound 1.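

In this assay the position on the carbonyl carbon does not depend on an anilide: with morpholin-4-yl there, a 1.3-fold higher number from compound 3 to compound 4 (0.12 log units; within the scatter) and a 1.9-fold lower number from compound 2 to compound 4 (0.29 log units; within the scatter) both stay within the scatter, while a 4.1-fold lower number from compound 1 to compound 4 (0.61 log units; beyond the scatter) lies beyond it. The earlier steps shown here only altered substituents on the aromatic ring, whereas this change removes that ring and the amide hydrogen together, and a non-aromatic ring with no hydrogen-bond donor still matches the two substituted anilides, compound 2 and compound 3, within the scatter and stands apart only from the bare anilide, compound 1. Nothing available explains why this exchange is tolerated.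

Going by these compounds, it remains open whether the ring oxygen of morpholin-4-yl matters, which piperidin-1-yl on the same carbonyl carbon would test, and whether any ring is needed at all, which a dimethylamino group would test. Among the compounds shown here, also open is whether the same tolerance holds when the morpholine amide is paired with a shorter or longer chain than the one in compound 4.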